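Swapping the aryl group on a thiazole acetic acid core

This account rests on a few compounds, and the source may have more. Where it says the series, first, only, none or still open, it means among the compounds named here.

Measured compounds:
- Compound 1, `O=C(O)Cc1sc(C(c2ccc(F)cc2)c2ccc(F)cc2)nc1-c1ccnc(N2CCC2)c1`: 660 nM
- Compound 2, `COc1ccc(C(c2ccccc2)c2nc(-c3ccc(Cl)cc3)c(CC(=O)O)s2)cc1`: 8.4 nM

The two measured compounds share a core carrying a carboxymethyl group and a diaryl-methyl substituent, but differ at several places at once, so no single change between them can be isolated. In an in vitro assay on HEK385-7 cells for displacement of a labelled ligand from prostaglandin D2 receptor 2 (Homo sapiens) (on this read-out higher numbers stand for weaker inhibition and lower numbers for stronger inhibition), compound 1 gives 660 nM, the highest of the two numbers. Compound 2 in this assay gives 8.4 nM, a much lower number, the gap to compound 1 lying well beyond the scatter.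

Compound 3, `CS(=O)(=O)Nc1cccc(-c2nc(C(c3ccc(F)cc3)c3ccc(F)cc3)sc2CC(=O)O)c1`, is not yet measured. It keeps the diaryl-methyl substituent and carboxymethyl group of compound 1 and changes only one place: 3-(methanesulfonamido)phenyl in place of 2-(azetidin-1-yl)pyridin-4-yl on an aromatic carbon. Nothing in the measured pair speaks directly to this change, since compound 2 differs from compound 1 at more than this position.

Given that compound 1 stands at the weak end of the measured range, a step toward stronger inhibition is expected for compound 3; the estimated step of an 11-fold lower number from compound 1 to compound 3 (1.04 log units; beyond the scatter) is modest and uncertain. In this assay compound 3 is estimated at 60 nM, within a range of 10 nM to 350 nM.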

Compound 3, half-maximal inhibitory concentration: 40 nM
Compound 3: the middle estimate sits 1.5-fold (0.18 log units) above what was measured; the range from low to high includes it.
By their numbers in this assay, from the lowest: compound 2; then compound 3; then compound 1.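

For the compounds shown here, this is the first reading of a single change at this place, the aromatic carbon next to the ring nitrogen and next to the ring atom that bears a carboxymethyl group. With the rest of compound 1 held fixed, 3-(methanesulfonamido)phenyl in place of 2-(azetidin-1-yl)pyridin-4-yl gives a 17-fold lower number from compound 1 to compound 3 (1.22 log units; beyond the scatter) in this assay, so what this place carries clearly matters for the read-out. The swap removes the four-membered non-aromatic ring and the ring nitrogen of the six-membered aromatic ring and adds a hydrogen-bond donor all at once, and no measurement is available that would explain the shift.

The compounds shown do not separate these features, so it remains open whether a plain phenyl ring with no substituent, or one carrying an acetamido group or a primary amine in place of the methanesulfonamido group, would give a similar number. As far as these compounds go, it also remains open whether 2-(azetidin-1-yl)pyridin-4-yl owes its higher number to the azetidine or to the pyridine, which a pyridine carrying a dimethylamino group or no substituent at all could begin to address.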